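The compounds below may be only part of what the source reports. "The series", "measured", "known", "first", "only" and "open" are said of these compounds alone.

Results so far in a functional assay on HCT-116 cells (Homo sapiens) for inhibition, read by sulforhodamine B assay, with a stated time of 48 h, tested at 50 uM; a lower number here means less inhibition of growth, a higher number more inhibition of growth at the concentration tested
- compound 1 `COc1cc(/C=C/C(=O)/C=C/c2cccc3ccccc23)ccc1OCc1cn(CCOc2cc(=O)oc3ccccc23)nn1` gives 83%
- compound 2 `COc1cc(/C=C/C(=O)/C=C/c2cccc3ccccc23)ccc1OCc1cn(CCCCCOc2cc(=O)oc3ccccc23)nn1` gives 42%
- compound 3 `COc1cccc(/C=C/C(=O)/C=C/c2ccc(OCc3cn(CCCCCOc4cc(=O)oc5ccccc45)nn3)c(OC)c2)c1` gives 36%

Compound 1 stands highest of the three at 83%, and the other two values both lie beneath it by more than the scatter. The next compound to be tested is compound 4 `COc1ccc(/C=C/C(=O)/C=C/c2ccc(OCc3cn(CCOc4cc(=O)oc5ccccc45)nn3)c(OC)c2)cc1OC`, which differs from compound 1 in one place: 3,4-dimethoxyphenyl in place of naphthalen-1-yl on a double-bonded chain carbon bound to a double-bonded chain carbon. Going by the values given here, only one measured step resembles this swap, a number 6 percentage points lower from compound 2 to compound 3 (within the scatter), where 3-methoxyphenyl takes the place of naphthalen-1-yl on the same kind of chain carbon. That step lies within the scatter, so it gives no sign that losing naphthalen-1-yl matters much. It is only weak guidance, however, since it started from a much lower value and its compounds differ from compound 1 elsewhere too. In this assay, then, the expected change is small and downward, with no clear step beyond the scatter, at a number 8 percentage points lower from compound 1 to compound 4 (within the scatter). Compound 4 is estimated to give 75%, with an expected range of 50% to 92%.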

Compound 4, percent growth inhibition at one concentration: 82%
Compound 4: middle estimate off by 7 percentage points, on the low side, within the range that was stated.
By their numbers in this assay, from the lowest: compounds 3 and 2 (each within the scatter of the next); then compounds 4 and 1 (each within the scatter of the next).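

Swapping naphthalen-1-yl for 3,4-dimethoxyphenyl in this assay gives a number 1 percentage points lower from compound 1 to compound 4 (within the scatter), so at this position on the core of compound 1, high growth inhibition does not depend on having 2 six-membered aromatic rings, as one such ring carrying 2 hydrogen-bond acceptors serves as well. Going by these compounds alone, the only similar swap seen earlier started from compound 2 at 42%, so it could not show whether a value as high as that of compound 1 would survive such a change. No measurement here explains why the two groups match.

Whether this position needs an aromatic ring at all remains open, since every group shown there has one. It is also unknown whether a phenyl ring bearing an amine or a carboxylic acid in place of the two methoxy groups would match these results.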